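Swapping Methoxy for Amino on the Aryl Ether

The source may report more compounds than this note shows. Statements on the series, on what has been measured and on what is new or still open speak of the compounds shown alone.

Of the compounds shown here, three sharing one core have been measured in a functional assay on L1210 cells (Mus musculus) for antiproliferative activity, read by cell counting, with a stated time of 96 h; a lower number here means a stronger inhibitor, a higher number a weaker inhibitor. Compound 1 `CC(=O)c1ccc(Oc2ccccc2NC(C)=C2C(=O)CC(c3ccccc3)CC2=O)cc1` gives 190 nM in this assay, compound 2 `COc1ccc(Oc2ccccc2NC(C)=C2C(=O)CC(c3ccccc3)CC2=O)cc1` gives 140 nM, and compound 3 `COc1ccc(Oc2ccccc2NC(C)=C2C(=O)CC(c3ccccc3)CC2=O)cc1OC` gives 65 nM. Compound 2 thus stands second highest of the three numbers: the nearest neighbour is compound 1, separated by a 1.4-fold lower number from compound 1 to compound 2 (0.13 log units; within the scatter), which lies within the scatter, whereas a 2.2-fold lower number from compound 2 to compound 3 (0.33 log units; beyond the scatter) and a 2.9-fold lower number from compound 1 to compound 3 (0.47 log units; beyond the scatter) are modest steps beyond it.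

Compound 4 `CC(Nc1ccccc1Oc1ccc(N)cc1)=C1C(=O)CC(c2ccccc2)CC1=O` differs from compound 2 in one place: amino in place of methoxy on an aromatic carbon. For the measured compounds named here, no measured step here exchanges a methoxy for an amino group, so the closest guide is how little the substituents on this ring have mattered so far. Replacing acetyl by methoxy, a 1.4-fold lower number from compound 1 to compound 2 (0.13 log units; within the scatter), stayed within the scatter, and adding a second methoxy, a 2.2-fold lower number from compound 2 to compound 3 (0.33 log units; beyond the scatter), moved the number only modestly. A change of similar size is therefore expected for compound 4 in this assay, in no firm direction and quite possibly within the scatter, a 1.1-fold lower number from compound 2 to compound 4 (0.03 log units; within the scatter). Compound 4 is estimated at 130 nM, with a range from 50 nM to 350 nM.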

Compound 4, half-maximal inhibitory concentration: 40 nM
Beside the measured number, compound 4's estimate is 3.3-fold (0.51 log units) above it; the measured number lies below the stated range.
By their numbers in this assay, from the lowest: compounds 4 and 3 (each within the scatter of the next); then compounds 2 and 1 (each within the scatter of the next).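

In this assay, the aromatic carbon para to a large group now proves sensitive to what it carries: amino in place of methoxy gives a 3.5-fold lower number from compound 2 to compound 4 (0.54 log units; beyond the scatter), and amino in place of acetyl gives a 4.8-fold lower number from compound 1 to compound 4 (0.68 log units; beyond the scatter), whereas the earlier exchange of one group for another on this carbon stayed within the scatter. For the compounds shown here, the step of a 1.6-fold lower number from compound 3 to compound 4 (0.21 log units; within the scatter) also stays within the scatter, so the single amino group of compound 4 reaches the same level as the two methoxy groups of compound 3, and the two compounds cannot be ranked. Amino brings a hydrogen-bond donor where methoxy has none, but nothing available here links that difference, or any other property, to the lower number.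

Going by these compounds, it remains open whether the gain depends on a free amino group, or whether a hydroxyl, a dimethylamino or an acetamido group on the same carbon would give a similar number. Also open, on these data alone, is whether a methoxy group added to the amino-bearing ring of compound 4 would lower the number further, as the second methoxy did in compound 3.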